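The source may report more compounds than this note shows. Statements on the series, on what has been measured and on what is new or still open speak of the compounds shown alone.

Values so far in a functional assay on A2780 cells (Homo sapiens) for inhibition, read by sulforhodamine B assay (a lower number here means a stronger inhibitor of growth, a higher number a weaker inhibitor of growth), are these.
- Compound 1 `Cc1ccc2[nH]c(-c3ccc(-c4ccc(-c5ccc(N(C)C)cc5)cc4)cc3)nc2c1` gives 2210 nM
- Compound 2 `COc1cc(-c2ccc(-c3ccc(-c4nc5cc(C)ccc5[nH]4)cc3)cc2)cc(OC)c1OC` gives 190 nM
- Compound 3 `Fc1ccc(-c2ccc(-c3ccc(-c4nc5ccccc5[nH]4)cc3)cc2)cc1` gives 48200 nM

Compound 3, at 48200 nM, has the highest number of the three, which makes it the weakest growth inhibitor in this small set. Compound 1 and compound 2 both lie well below it, beyond the usual scatter of repeat measurements.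

The next compound is compound 4 `COc1ccc(-c2ccc(-c3ccc(-c4nc5ccccc5[nH]4)cc3)cc2)cc1OC`, with 3,4-dimethoxyphenyl in place of 4-fluorophenyl on an aromatic carbon, para to a large group: 3,4-dimethoxyphenyl in place of 4-fluorophenyl on an aromatic carbon.

Among the measured compounds shown here, no two measured compounds differ in one place only, so no direct step can guide the expectation, and the three values offer only a loose comparison. The closest hint is compound 2, which also carries methoxy groups and gives 190 nM, although its core differs from that of compound 3. A large step down in this assay is therefore expected, towards stronger inhibition and well beyond the scatter. The estimate is a 48-fold lower number from compound 3 to compound 4 (1.68 log units; beyond the scatter).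

For compound 4 the expected value is 1000 nM, with an estimated range from 150 nM to 8000 nM.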

Compound 4, concentration for 50% growth inhibition: 21600 nM
Beside the measured number, compound 4's estimate is 22-fold (1.33 log units) below it, outside the stated range (above it).
By their numbers in this assay, from the lowest: compound 2; then compound 1; then compound 4; then compound 3.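

In this assay, among the compounds shown here, replacing 4-fluorophenyl with 3,4-dimethoxyphenyl on this aromatic carbon gives a 2.2-fold lower number from compound 3 to compound 4 (0.35 log units; beyond the scatter), the first direct reading of a single change in this set. The step is beyond the usual scatter but modest: the larger group, with its two hydrogen-bond acceptors, moves growth inhibition only a little, and compound 4 still gives 21600 nM in this series. Nothing measured here explains why the change has this effect.

Since the whole ring is exchanged in one step, the loss of the fluorine cannot be separated from the gain of the two methoxy groups. From the compounds shown here alone, whether a hydroxyl group or a carboxylic acid on this ring would shift the number further remains open.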